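This account rests on a few compounds, and the source may have more. Where it says the series, first, only, none or still open, it means among the compounds named here.

Working notes on the series. Going by the values given here, compound 3 `CCOc1cccc(-c2ccc([C@H]3S[C@@H](C)C(=O)Nc4c3c(C)nn4-c3ccccc3C)cc2)c1` gives 13% in an assay on isolated protein for agonist activity at Bile acid receptor (Homo sapiens), read by AlphaScreen, with a stated time of 30 min (a lower number here means a smaller maximal response, a higher number a larger maximal response), the lowest of the three numbers measured so far. Compound 2 `COc1ccc(Oc2ccc([C@H]3S[C@@H](C)C(=O)Nc4c3c(C)nn4-c3ccccc3C)cc2)cc1` gives 70% in this assay, and compound 1 `CCc1ccccc1-n1nc(C)c2c1NC(=O)[C@H](C)S[C@@H]2c1ccc(Oc2ccccc2)cc1` gives 190% in this assay. Among the compounds with values here, the one measured step that changes the group at the same place is a number 57 percentage points lower from compound 2 to compound 3 (beyond the scatter); it is the only step that bears on the present change, and it shows that exchanging the group on this aromatic carbon can move the maximal response a long way. Compound 4 `Cc1ccccc1-n1nc(C)c2c1NC(=O)[C@H](C)S[C@@H]2c1ccc(Oc2ccccc2)cc1` differs from compound 3 by phenoxy in place of 3-ethoxyphenyl on an aromatic carbon. Within the data shown here, compound 4 shares the phenoxy group with compound 1 and the rest of its core with compound 2 and compound 3; compound 1 and compound 2 both stand well above compound 3 in this assay, but no step between either of them and compound 4 has been measured, so their values can serve only as a rough guide. Given the large step of a number 57 percentage points lower from compound 2 to compound 3 (beyond the scatter) at this same carbon, a step upward in this assay is expected, estimated as a number 107 percentage points higher from compound 3 to compound 4 (beyond the scatter). Compound 4 is therefore estimated at 120% in this assay, with an expected range from 60% to 190%.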

Compound 4, largest response reached (reported as efficacy), in percent of the reference or control that the assay uses: 118%
The estimate for compound 4 lay 2 percentage points above the measured number; low and high end bracket the measured number.
By their numbers in this assay, from the lowest: compound 3; then compound 2; then compound 4; then compound 1.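

On this aromatic carbon, para to a large group, the size of the response in this assay depends strongly on the group present: phenoxy in place of 3-ethoxyphenyl gives a number 105 percentage points higher from compound 3 to compound 4 (beyond the scatter) and so reverses the earlier fall at this place. The step of a number 48 percentage points higher from compound 2 to compound 4 (beyond the scatter) shows that hydrogen in place of methoxy on the outer aromatic ring also raises the maximal response, so the phenoxy compounds do not all sit at one level. The response also moves with a change elsewhere on the molecule, since hydrogen in place of methyl on a saturated chain carbon bound to an aromatic carbon gives a number 72 percentage points lower from compound 1 to compound 4 (beyond the scatter) and this change counts for much in the series. Nothing available explains the size or direction of these steps.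

On these data alone, it remains open how a carboxylic acid or an amine in place of the methoxy on the outer ring would move the maximal response in this assay and whether a longer chain in place of the ethyl of compound 1 would raise it further. Also open, as far as these compounds go, is whether 3-ethoxyphenyl would keep its low response on the core of compound 1.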